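Aryl group step from compound 3 to compound 4

This account rests on a few compounds, and the source may have more. Where it says the series, first, only, none or still open, it means among the compounds named here.

In a functional assay on LoVo cells (Homo sapiens) for inhibition, read by MTT assay, with a stated time of 24 h (a higher number here means a weaker inhibitor, a lower number a stronger inhibitor), three compounds that share one core and differ in the aryl group on an aromatic nitrogen have been measured. Compound 1 (`CC1(C)[C@H]2CC[C@]1(C)N(Cc1cn(-c3cccc(F)c3)nn1)C(=O)C2`) gives 90 nM and compound 2 (`CC1(C)[C@H]2CC[C@]1(C)N(Cc1cn(-c3ccc(C#N)cc3)nn1)C(=O)C2`) gives 90 nM. Compound 3 (`CC1(C)[C@H]2CC[C@]1(C)N(Cc1cn(-c3ccccc3F)nn1)C(=O)C2`) gives 40 nM, the lowest of the three numbers.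

Compound 4 (`CC1(C)[C@H]2CC[C@]1(C)N(Cc1cn(-c3cccc(Cl)c3)nn1)C(=O)C2`) is still unmeasured. It carries 3-chlorophenyl in place of 2-fluorophenyl on an aromatic nitrogen.

The most relevant measured change is 2-fluorophenyl in place of 3-fluorophenyl, which shows a 2.3-fold lower number from compound 1 to compound 3 (0.35 log units; beyond the scatter). Replacing 4-cyanophenyl with 2-fluorophenyl shows a 2.3-fold lower number from compound 2 to compound 3 (0.35 log units; beyond the scatter). Replacing 3-fluorophenyl with 4-cyanophenyl shows no change at the digits printed from compound 1 to compound 2 (within the scatter). Only the 2-fluorophenyl compound stands apart among these three, and no chlorophenyl compound has been measured. The closest named group is therefore the 3-fluorophenyl of compound 1, at 90 nM, and this is a weak guide.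

The expected step is a 2.1-fold higher number from compound 3 to compound 4 (0.33 log units; beyond the scatter), a modest move toward a higher number, similar in size to the measured steps. For compound 4 the estimate is 85 nM, with an expected range of 35 nM to 200 nM.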

Compound 4, half-maximal inhibitory concentration: 70 nM
The estimate for compound 4 lay 1.2-fold (0.08 log units) above the measured number; measured number inside the range.
By their numbers in this assay, from the lowest: compounds 3, 4, 1 and 2 (each within the scatter of the next, the first and the last beyond it).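

Working notes on the aryl group: in this assay, the first halogen exchange on the aryl ring, chloro in place of fluoro on an aromatic carbon, gives a 1.3-fold lower number from compound 1 to compound 4 (0.11 log units; within the scatter), so the two 3-halophenyl groups cannot be told apart here. The other two new steps, a 1.8-fold higher number from compound 3 to compound 4 (0.24 log units; within the scatter) and a 1.3-fold lower number from compound 2 to compound 4 (0.11 log units; within the scatter), are also within the scatter, so 3-chlorophenyl cannot be separated from any of the three earlier aryl groups, and the 2-fluorophenyl of compound 3 no longer stands clear of every other member of the series, although it remains apart from the 3-fluorophenyl and 4-cyanophenyl groups. No supporting measurement is available to explain any of these steps.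

Still open, on these data alone, is whether the difference between the 2-fluorophenyl and 3-fluorophenyl groups also holds for chloro, which a 2-chlorophenyl group would test directly against the 3-chlorophenyl group. Also open is whether this aryl position tolerates groups of another kind, such as a 3-aminophenyl, a 3-methoxyphenyl or a ring bearing a carboxylic acid, since the substituents shown are limited to fluoro, chloro and nitrile.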